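The source may report more compounds than this note shows. Statements on the series, on what has been measured and on what is new or still open speak of the compounds shown alone.

Of the compounds shown here, three have so far been measured in an assay on cells for inhibition of cytochrome P450 11B2, mitochondrial (Homo sapiens), read by HTRF; on this read-out higher numbers stand for weaker inhibition and lower numbers for stronger inhibition. Compound 1 `C[C@@H](NS(C)(=O)=O)c1cncc(N2C(=O)c3ccc(Cl)cc3C2(C)C)c1` gives 8 nM, the lowest of the numbers shown. Compound 3 `CCS(=O)(=O)N[C@@H]1CCCc2c1cncc2N1Cc2cc(Cl)ccc2C1=O` gives 40 nM, a gap from compound 1 that lies beyond the usual scatter. For compound 2 `CN(C(=O)c1ccc(C#N)cc1)c1cccnc1` only a limit is recorded: > 3000 nM, which is the limit of > 3000 nM in this assay, at which 1 of the 3 values shown sits. Compound 4 `CCC(=O)NCc1cncc(N2C(=O)c3ccc(Cl)cc3C2(C)C)c1` has not yet been measured. It differs from compound 1 in one place: a group of 6 heavy atoms (4 carbon, 1 nitrogen, 1 oxygen; no ring) in place of a group of 7 heavy atoms (3 carbon, 1 nitrogen, 2 oxygen, 1 sulfur; no ring), on an aromatic carbon. Among the compounds with values here, no two measured compounds differ by a single change of this kind, so the size of the shift is uncertain. The number for compound 4 is estimated at 30 nM, within a range of 8 nM to 120 nM. That estimate amounts to an expected 3.8-fold higher number from compound 1 to compound 4 (0.57 log units; beyond the scatter), a modest loss.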

Compound 4, half-maximal inhibitory concentration: 282 nM
Estimate against measurement, compound 4: 9.4-fold (0.97 log units) below; measured number above the stated range.
By their numbers in this assay, from the lowest: compound 1; then compound 3; then compound 4. At a limit, above all of these: compound 2.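

In this assay putting (propanoylamino)methyl on this aromatic carbon in place of the original group gives a 35-fold higher number from compound 1 to compound 4 (1.55 log units; beyond the scatter) and so marks a large step for one change. Within the data shown here, no earlier pair differed in a single place, so this is the first sign that this position does not accept every group of similar size. Nothing measured here accounts for the loss.

From the compounds shown here alone, the change swaps several features at once, including the defined stereocentre, so which of them matters stays open. Going by these compounds, how an amine, a carboxylic acid or a longer chain would fare at this position also stays open.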